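The source may report more compounds than this note shows. Statements on the series, on what has been measured and on what is new or still open speak of the compounds shown alone.

Compound 1 `CC(C(=O)NCc1ccc(C(F)(F)F)nc1SCCCN1CCCCC1)c1ccc(NS(C)(=O)=O)c(F)c1`: 3 nM; compound 2 `CC(C(=O)NCc1ccc(C(F)(F)F)nc1SCCC(=O)O)c1ccc(NS(C)(=O)=O)c(F)c1`: "not active" (no number reported); compound 3 `CC(C(=O)NCc1ccc(C(F)(F)F)nc1[S+]([O-])C1CCCCC1)c1ccc(NS(C)(=O)=O)c(F)c1`: "not active" (no number reported).

In an assay on CHO-K1 cells for antagonist activity at transient receptor potential cation channel subfamily V member 1 (Homo sapiens), read by FLIPR (on this read-out higher numbers stand for weaker inhibition and lower numbers for stronger inhibition), compound 1 gives 3 nM. Compound 2 is reported as "not active" (no number reported), and compound 3 is likewise reported as "not active" (no number reported). Compound 2 therefore stands without any number, alongside compound 3, while only compound 1 carries one. Compound 4 `CC1CCC(Sc2nc(C(F)(F)F)ccc2CNC(=O)C(C)c2ccc(NS(C)(=O)=O)c(F)c2)CC1` differs from compound 2 in one place: 4-methylcyclohexyl in place of 2-carboxyethyl on a sulfur. With the 2-carboxyethyl gone, compound 4 is expected to move in this assay toward stronger inhibition by a step well beyond the scatter, reaching a measurable number; compound 3, which also lacks the 2-carboxyethyl yet reads "not active" (no number reported), counts against this expectation. Compound 4 is estimated at 20 nM, with a range from 3 nM to 300 nM.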

Compound 4, inhibition constant: 0.5 nM
Compound 4: middle estimate off by 40-fold (1.60 log units), on the high side; the whole stated range lies above it.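

In this assay, the sulfur accepts a six-membered ring of carbon only with no hydrogen-bond donor or acceptor: compound 4 carries a number, whereas compound 2, with its 2-carboxyethyl, has none. Putting 4-methylcyclohexyl in place of 3-(piperidin-1-yl)propyl on that sulfur gives a 6.0-fold lower number from compound 1 to compound 4 (0.78 log units; beyond the scatter), so a piperidine at the end of a chain is not needed for strong inhibition in this series. Nothing at hand bears on why this change has these effects. The compounds shown leave open whether the methyl of compound 4 contributes, and how an unsubstituted cyclohexyl or a phenyl on the same sulfur would read.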